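Cyano for methyl on the aryl ring of compound 3

The source may hold more compounds than are shown below. What is called first, only, known or untested is meant among the compounds shown, and "the series" means these compounds.

The series shares a core carrying a phenyl on the ring nitrogen and a substituted aryl on the ring carbon. Compound 2 `Cc1ccc(-c2cs/c(=N/NC(=O)CSc3nnnn3-c3ccccc3)n2-c2ccccc2)cc1` and compound 3 `Cc1ccc(-c2cs/c(=N/NC(=O)CSc3nncn3C)n2-c2ccccc2)cc1` differ only in the group on the sulfur. In a functional assay on C6 cells (Rattus norvegicus) for cytotoxicity, read by MTT assay, with a stated time of 24 h (on this read-out lower numbers stand for stronger inhibition and higher numbers for weaker inhibition), compound 2 gives 14.7 ug/mL, while compound 3 gives 56 ug/mL, the higher of the two numbers; the step of a 3.8-fold higher number from compound 2 to compound 3 (0.58 log units; beyond the scatter) lies beyond the scatter. Compound 1 `N#Cc1ccc(-c2cs/c(=N/NC(=O)CSc3ncccn3)n2-c2ccccc2)cc1` carries the cyano-substituted aryl together with the pyrimidinyl sulfur group, but in this assay compound 1 gives "not determined" (no result reported), so it offers no anchor.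

Compound 4 `Cn1cnnc1SCC(=O)N/N=c1/scc(-c2ccc(C#N)cc2)n1-c1ccccc1` arises from compound 3 by cyano in place of methyl on an aromatic carbon. Within the data shown here, none of the measured steps touches that aryl ring: the only step in hand concerns the sulfur group, not the aryl substituent, and compound 1, the only other cyano-bearing compound, was not determined. Nothing therefore points to a change beyond the scatter, and compound 4 is expected to sit close to compound 3 in this assay, with an estimated step of a 1.1-fold lower number from compound 3 to compound 4 (0.05 log units; within the scatter). The estimate for compound 4 is 50 ug/mL, within a range from 18 ug/mL to 140 ug/mL.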

Compound 4, half-maximal inhibitory concentration: > 200 ug/mL
Compound 4 was reported as a limit; the forecaster's own chance of this, stated with the estimate: 10%; middle value at least 4.0-fold (0.60 log units) from the limit.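

Among these compounds, the aryl substituent, which no earlier step had touched, proves to count in this assay: with the 4-methyl-4H-1,2,4-triazol-3-yl group held fixed on the sulfur, the change from 4-methylphenyl to 4-cyanophenyl gives an at least 3.5-fold higher number from compound 3 to compound 4 (0.55 log units; beyond the scatter), towards weaker inhibition. Compound 4 is reported only as a limit and not as a number, so this step has a lower bound but no upper end: the limit of > 200 ug/mL in this assay, at which 1 of the 4 values shown sits. Both the group on the sulfur and the substituent on this aryl ring have now given a step beyond the scatter.

On these data alone, whether cyano for methyl would act the same way with 1-phenyl-1H-tetrazol-5-yl on the sulfur stays open. So does how a methoxy group, an amine or a carboxylic acid would read in this place on the aryl ring.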